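The source may hold more compounds than are shown below. What is called first, only, known or untested is meant among the compounds shown, and "the series" means these compounds.

Working notes on the series.

Compound 2, `COc1cc(N2CCNCC2)c2c(c1)N(S(=O)(=O)c1ccccc1F)CCO2`, holds the lowest of the two numbers recorded so far: in an assay on HEK293 cells for displacement of a labelled ligand from 5-hydroxytryptamine receptor 6 (Homo sapiens) (a higher number here means a weaker inhibitor, a lower number a stronger inhibitor), compound 2 gives 0.159 nM. Its nearest neighbour is compound 1, `Cc1cc(N2CCNCC2)c2c(c1)N(S(=O)(=O)c1ccccc1)CCO2`, which differs from it in two places at once; in this assay compound 1 gives 2.51 nM. Among the compounds with values here, the gap between these two values lies well beyond the usual scatter, but with no single-point step between them nothing can be assigned to either change on its own.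

The next compound, compound 3, `COc1cc(N2CCNCC2)c2c(c1)N(S(=O)(=O)c1ccccc1)CCO2`, is not yet measured. It differs from compound 2 by one change only: hydrogen in place of fluoro on an aromatic carbon. Within the data shown here, no step between measured compounds isolates that change, so no measured size can be quoted for it. Within what the two measured values show, removal of the fluoro is expected to move this assay by a modest amount, toward a higher number, and possibly by no more than the scatter. For compound 3 the expected value in this assay is 0.4 nM, with a range from 0.12 nM to 1.3 nM, which corresponds to an expected step of a 2.5-fold higher number from compound 2 to compound 3 (0.40 log units; beyond the scatter).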

Compound 3, inhibition constant: 0.398 nM
For compound 3 the middle estimate is 1.0-fold (0.00 log units) above the measured one; low and high end bracket the measured number.
By their numbers in this assay, from the lowest: compound 2; then compound 3; then compound 1.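

Compound 3 separates the two changes that were joined in the earlier comparison, so each can now be read alone in this assay. With methoxy held constant, 2-fluorophenyl to phenyl gives a 2.5-fold higher number from compound 2 to compound 3 (0.40 log units; beyond the scatter), which shows that a fluoro ortho to a large group on this aromatic ring carries a real if modest gain in this series, not a change lost in the scatter. With the unsubstituted phenyl held constant, methoxy in place of methyl on the other aromatic carbon gives a 6.3-fold lower number from compound 1 to compound 3 (0.80 log units; beyond the scatter), so that site also responds beyond the scatter, and both single changes favour the lower number.

Still open, from the compounds shown here alone, is whether the fluoro step holds when methyl stands in place of methoxy, and whether a chloro or trifluoromethyl at the fluoro position, or an ethoxy in place of the methoxy, would extend either step or reverse it. Nothing at hand gives a reason for the size or direction of either step.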